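The source may hold more compounds than are shown below. What is called first, only, known or untested is meant among the compounds shown, and "the series" means these compounds.

Going by the values given here, compound 1 `CCC(C)C(=O)Nc1c(C(O)(C(F)(F)F)C(F)(F)F)ccc2ccccc12` gives 177000 nM in an assay on LtK cells with ATP-sensitive inward rectifier potassium channel 11 (Homo sapiens) as the target (a higher number here means that more compound is needed for the effect, a lower number that less compound is needed), while compound 2 `O=C(Nc1c(C(O)(C(F)(F)F)C(F)(F)F)ccc2ccccc12)c1cccc([N+](=O)[O-])c1` gives 117 nM, the lowest of the two numbers; the change a 1500-fold lower number from compound 1 to compound 2 (3.18 log units; beyond the scatter) is the only measured step. Compound 3 `O=C(Nc1c(C(O)(C(F)(F)F)C(F)(F)F)ccc2ccccc12)c1ccc(Cl)c(Cl)c1` differs from compound 2 by 3,4-dichlorophenyl in place of 3-nitrophenyl on a carbonyl carbon. That step swaps one six-membered aromatic ring of carbon only for another on the carbonyl carbon, so the large gain seen in compound 2 from a 1500-fold lower number from compound 1 to compound 2 (3.18 log units; beyond the scatter) should largely stay, and no step beyond the scatter is expected. Compound 3 is therefore estimated at 150 nM, within 30 nM to 800 nM, meaning an expected step of a 1.3-fold higher number from compound 2 to compound 3 (0.11 log units; within the scatter).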

Compound 3, half-maximal effective concentration: 194 nM
Beside the measured number, compound 3's estimate is 1.3-fold (0.11 log units) below it; low and high end bracket the measured number.
By their numbers in this assay, from the lowest: compounds 2 and 3 (each within the scatter of the next); then compound 1.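

In this assay, replacing the 3-nitrophenyl with 3,4-dichlorophenyl on the carbonyl carbon gives a 1.7-fold higher number from compound 2 to compound 3 (0.22 log units; within the scatter), so the nitro group is not required for a low number in this series. The ring that enters has no hydrogen-bond acceptors, yet replacing sec-butyl with it still gives a 910-fold lower number from compound 1 to compound 3 (2.96 log units; beyond the scatter). No measured evidence accounts for either step. The compounds shown leave open whether an unsubstituted phenyl, a pyridine ring or a cyclohexyl group on the carbonyl carbon would keep this low number.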